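Amide substituent change in a cytotoxicity series: working notes

The source may report more compounds than this note shows. Statements on the series, on what has been measured and on what is new or still open speak of the compounds shown alone.

Measured so far:
- Compound 1 `C=CC1=C(C(=O)O)C(c2ccc(OC)cc2)OC1`: in a functional assay on HeLa cells (Homo sapiens) for cytotoxicity, read by MTT assay, with a stated time of 24 h (on this read-out higher numbers stand for weaker inhibition and lower numbers for stronger inhibition), compound 1 gives 44300 nM.
- Compound 2 `C=CC1=C(C(=O)Nc2ccccc2OC)C(c2ccc(F)cc2)OC1`: in this assay compound 2 gives only a limit of the assay, > 100000 nM.

Among the measured compounds shown here, two compounds carry values, and they differ in more than one place, so no single step between them is counted; what the two values show is that compound 1 returns a number while compound 2 does not. Compound 2 stands at the limit of > 100000 nM in this assay, at which 1 of the 2 values shown sits, so its position on the shown numbers is known only as a limit, not as a value.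

Compound 3 `C=CC1=C(C(=O)NCCCCC)C(c2ccc(F)cc2)OC1` is the next compound to be tested in this assay. It differs from compound 2 by pentyl in place of 2-methoxyphenyl on an amide-type nitrogen. For the measured compounds named here, no measured step covers a change of this kind, so the expectation for this assay is a step of no size beyond the scatter, in neither direction. Compound 3 is therefore estimated at 100000 nM, with a range from 40000 nM to 250000 nM. The step this estimate implies, a number no higher from compound 2 to compound 3 (the limit leaves the size open), is expected to lie within the scatter, and a further limit rather than a number is the more likely outcome.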

Compound 3, half-maximal inhibitory concentration: > 100000 nM
Compound 3 was reported as a limit (the forecaster's own chance of this, stated with the estimate: 60%); the middle value lies on the limit itself.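

In this assay compound 3 gives > 100000 nM, a limit of the assay and not a number. Compound 2 also stands at a limit, so no step between compound 2 and compound 3 can be read: the limit of > 100000 nM in this assay, at which 2 of the 3 values shown sit.

The compounds shown leave open whether any amide substituent on the core of compound 2 returns a number in this assay.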